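Aryl amide change from compound 3 to compound 4

The source may hold more compounds than are shown below. What is called first, only, known or untested is meant among the compounds shown, and "the series" means these compounds.

In an in vitro ADME assay on microsomes from liver (Mus musculus) for pharmacokinetics, read by LC-MS, with a stated time of 10 min, tested at 1 uM (a lower number here means slower removal, a higher number faster removal of the compound), compound 1 `COc1cccc(NC(=O)[C@H]2CN(C)C[C@@H]2c2ccc(/C=C/C(=O)Nc3ccccc3N)cc2)c1` gives 65 mL/min/kg and compound 2 `CN1C[C@H](C(=O)Nc2ccc(Cl)c(Cl)c2)[C@@H](c2ccc(/C=C/C(=O)Nc3ccccc3N)cc2)C1` gives 36 mL/min/kg while compound 3 `Cc1cc(NC(=O)[C@H]2CN(C)C[C@@H]2c2ccc(/C=C/C(=O)Nc3ccccc3N)cc2)ccc1Cl` gives 65 mL/min/kg at the level of compound 1 and within the scatter of compound 2. Compound 4 `CN1C[C@H](C(=O)Nc2ccccn2)[C@@H](c2ccc(/C=C/C(=O)Nc3ccccc3N)cc2)C1` carries pyridin-2-yl in place of 4-chloro-3-methylphenyl on an amide-type nitrogen. Going by the values given here, three steps bear on this only loosely: a 1.8-fold lower number from compound 1 to compound 2 (0.26 log units; within the scatter) and no change at the digits printed from compound 1 to compound 3 (within the scatter) on that nitrogen, and a 1.8-fold higher number from compound 2 to compound 3 (0.26 log units; within the scatter) on an aromatic carbon. All lie within the scatter, and none puts a hetero atom into that ring. No step beyond the scatter is therefore expected in this assay for this change. The expected step is a 1.3-fold lower number from compound 3 to compound 4 (0.11 log units; within the scatter) by estimate. Compound 4 is estimated at 50 mL/min/kg (25 mL/min/kg to 95 mL/min/kg).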

Compound 4, clearance: 40 mL/min/kg
Beside the measured number, compound 4's estimate is 1.3-fold (0.10 log units) above it, within the range that was stated.
By their numbers in this assay, from the lowest: compounds 2, 4, 1 and 3 (each within the scatter of the next).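

In this assay, pyridin-2-yl is the only ring on the amide-type nitrogen with a hetero atom, and the steps to it are a 1.6-fold lower number from compound 3 to compound 4 (0.21 log units; within the scatter) and a 1.1-fold higher number from compound 2 to compound 4 (0.05 log units; within the scatter) and a 1.6-fold lower number from compound 1 to compound 4 (0.21 log units; within the scatter). A ring with a hetero atom and no further group therefore stays within the scatter of all three substituted phenyl rings at this position. No measurement here gives a cause for these numbers.

Unsubstituted phenyl on that nitrogen would separate the ring nitrogen from the loss of the other ring groups. On these data alone, an amine or a carboxylic acid on the pyridin-2-yl ring remains open.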